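The compounds below may be only part of what the source reports. "The series", "measured", "known", "first", "only" and "open" are said of these compounds alone.

Three quinoxaline-type sulfones of a shared core have been measured in a functional assay on HCT-116 cells (Homo sapiens) for cytotoxicity, read by MTT assay, with a stated time of 72 h; on this read-out higher numbers stand for weaker inhibition and lower numbers for stronger inhibition. Compound 1 `O=S(=O)(c1ccccc1)c1nc2ccccc2nc1Nc1ccc(Cl)cc1` gives 2000 nM in this assay. Compound 2 `COc1ccc(Nc2nc3ccccc3nc2S(=O)(=O)c2ccc(C)cc2)cc1` reaches only the limit > 50000 nM in this assay, so its number is not known. Compound 3 `Cc1ccc(S(=O)(=O)c2nc3ccccc3nc2Nc2cccc(N)c2)cc1` gives 2390 nM in this assay, which is the highest of the two actual numbers, though compound 1 lies within the scatter of it. Among the compounds with values here, the one measured step in this set, an at least 20-fold lower number from compound 2 to compound 3 (1.32 log units; beyond the scatter), is large, and it runs from a value that was only the limit of > 50000 nM in this assay, at which 1 of the 3 values shown sits, to a real number.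

The next compound, compound 4 `Cc1ccc(S(=O)(=O)c2nc3ccccc3nc2Nc2ccc(Cl)cc2)cc1`, differs from compound 3 by 4-chlorophenyl in place of 3-aminophenyl on a nitrogen on an aromatic ring. Within the data shown here, no measured step covers exactly this exchange. What bears on it is compound 1, which carries the same 4-chlorophenyl on the same nitrogen and gives 2000 nM, a value within the scatter of compound 3. The methyl on the sulfonyl-bearing ring of compound 3 and compound 4 is the remaining difference from compound 1, and nothing here shows that it changes the number. The expected step in this assay, a 1.2-fold lower number from compound 3 to compound 4 (0.08 log units; within the scatter), is therefore none beyond the scatter. Compound 4 is estimated at 2000 nM, with a range from 700 nM to 6000 nM.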

Compound 4, half-maximal inhibitory concentration: 2050 nM
For compound 4 the middle estimate is 1.0-fold (0.01 log units) below the measured one; the measured number falls inside the stated range.
By their numbers in this assay, from the lowest: compounds 1, 4 and 3 (each within the scatter of the next). At a limit, above all of these: compound 2.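

In this assay, the group on this nitrogen can change without any readable effect, as a 1.2-fold lower number from compound 3 to compound 4 (0.07 log units; within the scatter) shows: 4-chlorophenyl and 3-aminophenyl cannot be told apart here, even though the hydrogen-bond donor and acceptor counted on 3-aminophenyl are absent from 4-chlorophenyl. The pair of compounds with and without the methyl now tests that group directly, and a 1.0-fold higher number from compound 1 to compound 4 (0.01 log units; within the scatter) shows that methyl in place of hydrogen on an aromatic carbon also leaves the number within the scatter. Chloro in place of methoxy on an aromatic carbon gives the only large new step, an at least 24-fold lower number from compound 2 to compound 4 (1.38 log units; beyond the scatter), but compound 2 has a limit and not a number, so the true size of this step stays unknown: the limit of > 50000 nM in this assay, at which 1 of the 4 values shown sits.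

Still open, as far as these compounds go, is whether fluoro or hydroxy in place of the chloro of compound 4 would leave the number unchanged, or whether a methoxy in place of the methyl on the sulfonyl-bearing ring would shift it. Also open, from the compounds shown here alone, is whether the large step is special to methoxy, which only compound 2 carries, or would also appear with a carboxylic acid in its place.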